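Replacing a biaryl arm with chloro: cytotoxicity of compound 3

The source may report more compounds than this note shows. Statements on the series, on what has been measured and on what is new or still open speak of the compounds shown alone.

Measured compounds:
compound 1 `CC1(c2ccc(-c3ccco3)cc2)CC(S(=O)(=O)c2ccc(F)cc2)=C(c2ccc(/C(N)=N\O)cc2)O1` — 4560 nM
compound 2 `CC1(c2ccc(-c3ccccc3C#N)cc2)CC(S(=O)(=O)c2ccc(F)cc2)=C(c2ccc(/C(N)=N\O)cc2)O1` — 9290 nM

Among the measured compounds shown here, in an ADME assay on J774.A1 cells (Mus musculus) for cytotoxicity, read by MTT assay, with a stated time of 72 h (a lower number here means that less compound is tolerated, a higher number that more compound is tolerated), compound 2 gives 9290 nM, the highest of the two numbers known, while compound 1 gives 4560 nM. For the measured compounds named here, the only step measured so far, a 2.0-fold higher number from compound 1 to compound 2 (0.31 log units; beyond the scatter), exchanges one aromatic group for another on the same aromatic carbon. Compound 3 `CC1(c2ccc(Cl)cc2)CC(S(=O)(=O)c2ccc(F)cc2)=C(c2ccc(/C(N)=N\O)cc2)O1` differs from compound 2 in one place: chloro in place of 2-cyanophenyl on an aromatic carbon. Going by the values given here, no measured step swaps an aromatic group for a single halogen atom, so the earlier step bears on this change only loosely: it shows that altering this position shifts the number by a modest amount rather than by a large one. A step within or just beyond the scatter, in either direction, is therefore expected, a 1.3-fold lower number from compound 2 to compound 3 (0.12 log units; within the scatter). Compound 3 is estimated at 7000 nM, with a range from 2500 nM to 25000 nM.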

Compound 3, half-maximal cytotoxic concentration: 31500 nM
Compound 3: the middle estimate sits 4.5-fold (0.65 log units) below what was measured; the measured number lies above the stated range.
By their numbers in this assay, from the lowest: compound 1; then compound 2; then compound 3.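

In this assay this aromatic carbon, para to a large group, proves more responsive than the earlier exchange of one aromatic group for another had shown: that exchange was a 2.0-fold higher number from compound 1 to compound 2 (0.31 log units; beyond the scatter) while chloro gives a 3.4-fold higher number from compound 2 to compound 3 (0.53 log units; beyond the scatter) and, set against the furan-2-yl group, a 6.9-fold higher number from compound 1 to compound 3 (0.84 log units; beyond the scatter). Of these three compounds, compound 3, which carries a single chlorine and no second ring here, is the best tolerated, and neither compound 1 nor compound 2 goes against the reading that the two aromatic groups sit lower than chloro. Nothing available gives a reason for this rise.

The compounds shown leave open whether the higher number follows from losing the aromatic ring or from the chlorine itself. A fluorine, a methyl group or an amine on the same carbon would help separate the two, and a saturated ring would test whether aromaticity matters at all.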